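The source may hold more compounds than are shown below. What is called first, only, known or untested is meant among the compounds shown, and "the series" means these compounds.

Compound 1 `COc1ccc(-c2ccc3c(c2)oc(=O)n3C(=O)NCCCCc2ccccc2)cc1`: 67 nM
Compound 2 `O=C(NCCCCc1ccccc1)n1c(=O)oc2ccc([N+](=O)[O-])cc21`: 3 nM
Compound 3 `COc1ccc(CCCCNC(=O)n2c(=O)oc3ccccc32)cc1`: 63 nM

The three measured compounds share a carbamate tail on a common bicyclic core, and all were tested in an assay on HEK293 cells for inhibition of acid ceramidase (Homo sapiens), with a stated time of 10 min; on this read-out higher numbers stand for weaker inhibition and lower numbers for stronger inhibition. Compound 1 gives 67 nM, which is the highest of the three numbers. Compound 3 sits closest to it at 63 nM, a gap that lies within the scatter, so the two cannot be ordered. Compound 2, with a nitro group on the core, gives 3 nM, a far lower number and well beyond the scatter.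

Compound 4 `O=C(c1ccc(Cl)cc1)c1ccc2c(c1)oc(=O)n2C(=O)NCCCCc1ccccc1` has not been measured. It differs from compound 1 in one place: (4-chlorophenyl)carbonyl in place of 4-methoxyphenyl on an aromatic carbon. Among the compounds with values here, no measured pair shows exactly this exchange, so the expected size of the step rests on what the three measured compounds show. Compound 2 shows that a different group at this site of the core can push the number down sharply, while compound 1 and compound 3 show that an aryl or an unsubstituted core land in the same region. The account therefore expects compound 4 to move toward the lower number, and estimates the step of a 4.5-fold lower number from compound 1 to compound 4 (0.65 log units; beyond the scatter) for compound 4. For compound 4 the estimate in this assay is 15 nM, with a range from 4 nM to 60 nM.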

Compound 4, half-maximal inhibitory concentration: 14 nM
Compound 4: middle estimate off by 1.1-fold (0.03 log units), on the high side; the range from low to high includes it.
By their numbers in this assay, from the lowest: compound 2; then compound 4; then compounds 3 and 1 (each within the scatter of the next).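

In this assay, within the data shown here, placing (4-chlorophenyl)carbonyl instead of 4-methoxyphenyl on this aromatic carbon gives a 4.8-fold lower number from compound 1 to compound 4 (0.68 log units; beyond the scatter) and is the first change that can be read at a single place on the shared core. It shows that the number at this position depends on the group attached there: the entering group keeps a six-membered aromatic ring of carbon only and has one more heavy atom than the group it replaces, yet the step lies beyond the scatter. No measurement on hand accounts for this step.

This one exchange brings in the carbonyl and the chlorine together and also moves the para substituent from methoxy to chlorine, so the compounds shown do not say which part of the change carries the step. A plain benzoyl group or a 4-chlorophenyl group joined directly to the core would separate those parts, and an amine or a carboxylic acid in place of the chlorine would test how much the far end of the entering group matters.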